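From cycloheptyl to pyrrolidin-3-yl on an aromatic nitrogen

A few compounds are considered here, and "the series" means these few. Any claim that something is new, unique, unknown or untested is made for them only; others in the source may bear on it.

Compound 1 `CN1C(=S)[C@@H](NC(=O)c2nc(Cc3ccccc3)n(C)n2)COc2ccccc21`: 2.5 nM
Compound 2 `CN1C(=S)[C@@H](NC(=O)c2nc(Cc3ccccc3)n(CCCCCC#N)n2)COc2ccccc21`: 3830 nM
Compound 3 `CN1C(=S)[C@@H](NC(=O)c2nc(Cc3ccccc3)n(C3CCCCCC3)n2)COc2ccccc21`: 5530 nM

In a functional assay on HT-29 cells (Homo sapiens) for inhibition, read by luminescence and CellTiter-Glo, with a stated time of 24 h (a lower number here means that less compound is needed, a higher number that more compound is needed for the effect), compound 3 sits at the high end of these numbers, with a 1.4-fold higher number from compound 2 to compound 3 (0.16 log units; within the scatter) and, far more sharply, a 2200-fold higher number from compound 1 to compound 3 (3.34 log units; beyond the scatter). Compound 4 `CN1C(=S)[C@@H](NC(=O)c2nc(Cc3ccccc3)n(C3CCNC3)n2)COc2ccccc21` is unmeasured and carries pyrrolidin-3-yl in place of cycloheptyl on an aromatic nitrogen. Among the measured compounds shown here, the steps that bear on it are a 1500-fold higher number from compound 1 to compound 2 (3.19 log units; beyond the scatter) and a 2200-fold higher number from compound 1 to compound 3 (3.34 log units; beyond the scatter). Both are large, and only compound 1, with methyl there, gives a low number. The entering ring is not methyl, so a moderate fall is expected, without a full return to compound 1. The expected change is a 7.9-fold lower number from compound 3 to compound 4 (0.90 log units; beyond the scatter). For compound 4 the estimate is 700 nM, with an expected range of 60 nM to 6000 nM.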

Compound 4, half-maximal effective concentration: 1070 nM
The estimate for compound 4 lay 1.5-fold (0.18 log units) below the measured number; the measured number falls inside the stated range.
By their numbers in this assay, from the lowest: compound 1; then compound 4; then compounds 2 and 3 (each within the scatter of the next).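

In this assay, among the compounds shown here, pyrrolidin-3-yl is the first group at this aromatic nitrogen to separate from the larger groups beyond the scatter, with a 5.2-fold lower number from compound 3 to compound 4 (0.71 log units; beyond the scatter) and a 3.6-fold lower number from compound 2 to compound 4 (0.55 log units; beyond the scatter) as its two steps. Even so, a 430-fold higher number from compound 1 to compound 4 (2.63 log units; beyond the scatter) remains a large step, so among these compounds only methyl gives a low number. Nothing shown here accounts for these steps.

The ring nitrogen and the smaller ring enter together in compound 4, so their shares stay apart unread. Cyclopentyl would address the ring alone, while ethyl or a 2-aminoethyl chain would probe the span just beyond methyl.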